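A few compounds are considered here, and "the series" means these few. Any claim that something is new, unique, unknown or untested is made for them only; others in the source may bear on it.

Compound 1 `CCN(CC)CN1C(=O)C(=O)c2c(Cl)cccc21` — in an ADME assay on 184B5 cells (Homo sapiens) for cytotoxicity, read by sulforhodamine B assay, with a stated time of 48 h (on this read-out higher numbers stand for weaker inhibition of growth and lower numbers for stronger inhibition of growth), compound 1 gives 22500 nM.
Compound 2 `CN(C)CN1C(=O)C(=O)c2ccccc21` — in this assay compound 2 gives 73700 nM.

Of the two measured compounds, compound 2 stands with the higher number, and its gap to compound 1 lies beyond the scatter. Compound 3 `CN(C)CN1C(=O)C(=O)c2c(Cl)cccc21` is not yet measured. Compared with compound 2 it carries chloro in place of hydrogen on an aromatic carbon. Going by the values given here, no measured pair shows this change alone, so the size of the step is uncertain. Compound 1, which also bears a chloro group, gives the lower number, so a moderate downward step a 2.1-fold lower number from compound 2 to compound 3 (0.32 log units; beyond the scatter) is expected. Compound 3 is estimated at 35000 nM, within a range from 12000 nM to 90000 nM.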

Compound 3, concentration for 50% growth inhibition: 130000 nM
Estimate against measurement, compound 3: 3.7-fold (0.57 log units) below, and the stated range ends below it.
By their numbers in this assay, from the lowest: compound 1; then compounds 2 and 3 (each within the scatter of the next).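

In this assay, chloro in place of hydrogen on this aromatic carbon gives a 1.8-fold higher number from compound 2 to compound 3 (0.25 log units; within the scatter), so this change alone does not separate the two compounds. Dimethylamino in place of diethylamino on the saturated chain carbon gives a 5.8-fold higher number from compound 1 to compound 3 (0.76 log units; beyond the scatter), the only one of these single changes that exceeds the scatter. Nothing available accounts for either step.

Going by these compounds, it remains open whether a methoxy group or a fluoro group on this aromatic carbon would behave as chloro does. A morpholine in place of the diethylamino group is also untested among the compounds shown here.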